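Two limit-bound pairs, one repeated swap of a ring for a chain

This account rests on a few compounds, and the source may have more. Where it says the series, first, only, none or still open, it means among the compounds named here.

Compound 1 `CCCNC(=O)c1cc(-n2cc(-c3ccccc3)nn2)ccc1O` carries a phenyl group on a five-membered aromatic ring with three nitrogens, together with an amide built from a propylamine. In a functional assay on RAW264.7 cells (Mus musculus) for inhibition, read by Griess assay, with a stated time of 20 h (on this read-out lower numbers stand for stronger inhibition and higher numbers for weaker inhibition), compound 1 gives > 20000 nM, which is a limit of the assay rather than a number. Compound 2 `CCCNC(=O)c1cc(-n2cc(CCC(C)C)nn2)ccc1O` differs from it in one place (isopentyl in place of phenyl on an aromatic carbon). In this assay compound 2 gives > 20000 nM, again a limit. The step that the two limits leave unreadable from compound 1 to compound 2 therefore cannot be sized, as the limit of > 20000 nM in this assay, at which 3 of the 3 values shown sit, shows.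

Compound 3 `O=C(c1ccc(-n2cc(-c3ccccc3)nn2)cc1O)N1CCCCC1` keeps the phenyl group but has its amide closed into a piperidine ring; how its core differs from that of compound 1 is not broken down here. In this assay compound 3 gives > 20000 nM, once more a limit.

Compound 4 `CC(C)CCc1cn(-c2ccc(C(=O)N3CCCCC3)c(O)c2)nn1`, not yet measured, stands to compound 3 as compound 2 stands to compound 1: the same change (isopentyl in place of phenyl on an aromatic carbon). Since the first occurrence of this change left both ends at the limit, and compound 3 itself sits at that limit, the step that the limit leaves unreadable from compound 3 to compound 4 is expected to be unreadable in the same way. Compound 4 is estimated in this assay at 40000 nM, with a likely range from 15000 nM to 150000 nM, most probably reported only as a limit.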

Compound 4, half-maximal inhibitory concentration: > 20000 nM
Compound 4: a limit, no number (the forecaster's own chance of this, stated with the estimate: 90%); the middle value lies beyond the limit too.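

The change from compound 3 to compound 4, isopentyl in place of phenyl, gives no step that can be read, because both values are limits and not numbers: the limit of > 20000 nM in this assay, at which 4 of the 4 values shown sit.

In this assay, from the compounds shown here alone, it remains open how strongly any of the four compounds inhibits, and whether isopentyl in place of phenyl changes that at all.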